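Replacing Dimethylamino with 4-Methylpiperazin-1-yl

This account rests on a few compounds, and the source may have more. Where it says the series, first, only, none or still open, it means among the compounds named here.

Of the compounds shown here, two have been measured so far.
Compound 1, `CCN1CCN(c2cc(C)c3cc(NC(=O)c4cccc(Cl)c4)ccc3n2)CC1`, gives 17800 nM in a functional assay on SK-BR-3 cells (Homo sapiens) for antiproliferative activity, read by MTT assay, with a stated time of 72 h; a higher number here means a weaker inhibitor, a lower number a stronger inhibitor.
Compound 2, `Cc1cc(N(C)C)nc2ccc(NC(=O)c3ccc(Cl)c(Cl)c3)cc12`, gives > 50000 nM in this assay; this is a limit of the assay, not a number.

Compound 2 therefore stands at the edge of what the assay can report: it is the one of the two that reached (the limit of > 50000 nM in this assay, at which 1 of the 2 values shown sits), whereas compound 1 returned a number. Among the compounds with values here, the two structures differ in more than one place, so no single step connects them, and nothing further can be said about how they compare.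

Compound 3, `Cc1cc(N2CCN(C)CC2)nc2ccc(NC(=O)c3ccc(Cl)c(Cl)c3)cc12`, differs from compound 2 in one place: 4-methylpiperazin-1-yl in place of dimethylamino on an aromatic carbon. No measured step of this kind exists among the compounds shown. The change is expected to bring a modest gain, an at least 1.6-fold lower number from compound 2 to compound 3 (0.22 log units; that floor lies within the scatter), possibly no larger than the scatter. Compound 3 is thus expected to give about 30000 nM, within 8000 nM to 100000 nM.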

Compound 3, half-maximal inhibitory concentration: 6320 nM
Compound 3: middle estimate off by 4.7-fold (0.68 log units), on the high side; measured number outside the range, below it.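

At the aromatic carbon next to the ring nitrogen, the choice of amine clearly matters: in this assay, 4-methylpiperazin-1-yl in place of dimethylamino gives an at least 7.9-fold lower number from compound 2 to compound 3 (0.89 log units; beyond the scatter). Within the data shown here, this is the first measured step of its kind. Among these compounds, only this one group differs between compound 2 and compound 3. The true size of the gain remains unknown, since the step is only a floor set by compound 2, whose value is a limit and not a number: the limit of > 50000 nM in this assay, at which 1 of the 3 values shown sits.

One pair cannot show which part of the new group carries the gain: the ring, its second nitrogen or the methyl group. A piperidin-1-yl or morpholin-4-yl group on the same carbon would help separate these possibilities.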